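The source may report more compounds than this note shows. Statements on the series, on what has been measured and on what is new or still open speak of the compounds shown alone.

Compound 1, `Cc1ccc(-c2nnc(-c3cccnc3)o2)cc1Nc1nccc(-c2cccnc2)n1`, gives > 30000 nM in a functional assay on HL-60 cells (Homo sapiens) for inhibition, read by MTT assay, with a stated time of 72 h; on this read-out lower numbers stand for stronger inhibition and higher numbers for weaker inhibition.
Compound 2, `Cc1nnc(-c2ccc(C)c(Nc3nccc(-c4cccnc4)n3)c2)o1`, gives > 30000 nM in this assay.

The value of compound 1 is a limit of the assay, not a number. The value of compound 2 is likewise a limit. Within the data shown here, the single measured step, a step that the two limits leave unreadable from compound 1 to compound 2, is unreadable, as summed up in the limit of > 30000 nM in this assay, at which 2 of the 2 values shown sit. Compound 2 therefore stands only at the limit, with no number to place it. Compound 3, `Cc1ccc(-c2nnc(-c3ccc(F)c(C(F)(F)F)c3)o2)cc1Nc1nccc(-c2cccnc2)n1`, differs from compound 2 by 4-fluoro-3-(trifluoromethyl)phenyl in place of methyl on an aromatic carbon. Among the measured compounds shown here, the one measured step concerns the same position, exchanging pyridin-3-yl for methyl, and left both values at the limit, so it gives no size to work from. Compound 1 carried an aromatic ring at that position and sat at the limit, so compound 3 is expected most likely to be reported only as a limit as well. Compound 3 is estimated at 30000 nM, within 6000 nM to 150000 nM. The expected step is a number no higher from compound 2 to compound 3 (the limit leaves the size open).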

Compound 3, half-maximal inhibitory concentration: > 30000 nM
Compound 3: only a limit was reported; the forecaster's own chance of this, stated with the estimate: 70%; the middle value sits exactly at the limit.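

Compound 3 also gives only a limit of the assay, not a number, so neither its step from compound 2 nor its step from compound 1 can be read: the limit of > 30000 nM in this assay, at which 3 of the 3 values shown sit.

The compounds shown leave open how strongly any of the three inhibits in this assay, and whether any group at this position would give a measurable value.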